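The source may report more compounds than this note shows. Statements on the series, on what has been measured and on what is new or still open speak of the compounds shown alone.

Measured so far:
compound 1 `CCCCCC[C@@H](O)C/C=C\CCCCCCCCSCCC(=O)NCc1ccc(O)c(OC)c1` — > 10000 nM
compound 2 `CCCCCCCCCCCCCCCCCCCC(=O)NCc1ccc(O)c(OC)c1` — 3100 nM
compound 3 `CCCCCCCC/C=C\CCCCCCCC(=O)N/N=C/c1ccc(O)c(OC)c1` — 120 nM

In an assay on HEK293 cells for antagonist activity at transient receptor potential cation channel subfamily V member 2 (Rattus norvegicus), read by fluorescence and calcium flux, with a stated time of 5 min (on this read-out higher numbers stand for weaker inhibition and lower numbers for stronger inhibition), compound 1 gives only a limit, > 10000 nM, and not a number; it stands at the limit of > 10000 nM in this assay, at which 1 of the 3 values shown sits. Compound 2 gives 3100 nM in this assay, and compound 3 gives 120 nM. Compound 4 `CCCCC/C=C\C/C=C\CCCCCCCCSCCC(=O)NCc1ccc(O)c(OC)c1` has not been measured. Its change from compound 1 is hept-1-en-1-yl in place of 1-hydroxyheptyl on a saturated chain carbon bound to a double-bonded chain carbon. Going by the values given here, no step between measured compounds is available to anchor this change, so the expectation rests on compound 1 standing at the limit while compound 2 and compound 3 return numbers. The step is estimated as an at least 3.3-fold lower number from compound 1 to compound 4 (0.52 log units; beyond the scatter), toward stronger inhibition, but with wide uncertainty. Compound 4 is expected near 3000 nM, with a range from 700 nM to 10000 nM.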

Compound 4, half-maximal inhibitory concentration: 1400 nM
Compound 4: middle estimate off by 2.1-fold (0.33 log units), on the high side; low and high end bracket the measured number.
By their numbers in this assay, from the lowest: compound 3; then compound 4; then compound 2. At a limit, above all of these: compound 1.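

In this assay, this position on a saturated chain carbon bound to a double-bonded chain carbon responds to the group it carries: hept-1-en-1-yl in place of 1-hydroxyheptyl gives an at least 7.1-fold lower number from compound 1 to compound 4 (0.85 log units; beyond the scatter). Compound 1 gives only a limit, > 10000 nM, not a number. The step therefore sets a minimum size, and its full size cannot be read: the limit of > 10000 nM in this assay, at which 1 of the 4 values shown sits.

On these data alone, it remains open whether loss of the hydroxyl or entry of the double bond carries the step, which plain heptyl at this place would separate. As far as these compounds go, how an amine or a carboxylic acid on this chain would read also stays open.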